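Replacing a Pyrimidine with an Open-Chain Oxime Ether

The source may hold more compounds than are shown below. What is called first, only, known or untested is meant among the compounds shown, and "the series" means these compounds.

Measured in a functional assay for activation of Alpha-1D adrenergic receptor (Homo sapiens); a higher number here means that more compound is needed for the effect, a lower number that less compound is needed:
- compound 1, `c1coc(-c2ccccc2NCC2=NCCN2)c1`: 16.2 nM
- compound 2, `Cc1cc(-c2ccccc2NCC2=NCCN2)on1`: < 100000 nM, which is a limit of the assay
- compound 3, `c1cnc(-c2ccccc2NCC2=NCCN2)nc1`: 81.3 nM

Compound 3 has the highest of the two readable numbers; its nearest neighbour is compound 1, and the step reads a 5.0-fold higher number from compound 1 to compound 3 (0.70 log units; beyond the scatter). The steps a step that the limit leaves unreadable from compound 1 to compound 2 and a step that the limit leaves unreadable from compound 2 to compound 3 cannot be sized owing to the limit of < 100000 nM in this assay, at which 1 of the 3 values shown sits.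

Compound 4, `CO/N=C(\C)c1ccccc1NCC1=NCCN1`, differs from compound 3 by a group of 5 heavy atoms (3 carbon, 1 nitrogen, 1 oxygen; no ring) in place of a group of 6 heavy atoms (4 carbon, 2 nitrogen; one six-membered aromatic ring with 2 hetero atoms), on an aromatic carbon. Within the data shown here, no measured step exchanges an aromatic ring for a group with no ring, so the one readable step is only a loose guide, and compound 2 shows that a ring exchange can also remove measurable activity.

The number for compound 4 is therefore expected to rise, the step being estimated as a 3.7-fold higher number from compound 3 to compound 4 (0.57 log units; beyond the scatter). Compound 4 is estimated at 300 nM, within 40 nM to 3000 nM.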

Compound 4, half-maximal effective concentration: < 5020 nM
Compound 4: a limit, no number (the forecaster's own chance of this, stated with the estimate: 15%); the middle value does not contradict the limit.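

Compound 4 gives a limit, not a number, so no step to compound 4 from compound 1, compound 2 or compound 3 can be read in this assay: the limit of < 5020 nM in this assay, at which 1 of the 4 values shown sits.

The compounds shown leave open whether a group with no ring at this place can match the activity of compound 1 or compound 3.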